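A few compounds are considered here, and "the series" means these few. Any claim that something is new, unique, unknown or untested is made for them only; others in the source may bear on it.

Three compounds have been measured in a functional assay on MDA-MB-231 cells (Homo sapiens) for inhibition, read by sulforhodamine B assay, tested at 10 uM; a lower number here means less inhibition, a higher number more inhibition at the concentration tested (going by the name of the read-out):
compound 1 `CN1CCN(c2ccc(C3=NN(C(=O)/C=C/c4ccccc4)C(c4ccc(N(C)C)cc4)C3)cc2)CC1` gives 35.9%
compound 2 `CN1CCN(c2ccc(C3=NN(S(C)(=O)=O)C(c4ccc(N(C)C)cc4)C3)cc2)CC1` gives 0.6%
compound 3 `CN(C)c1ccc(C2CC(c3ccc(-n4cncn4)cc3)=NN2C(=O)/C=C/c2ccccc2)cc1` gives 8.5%

Compound 2 differs from compound 1 in one place: methylsulfonyl in place of (2-phenylethenyl)carbonyl on an amine nitrogen in a ring This brought a number 35.3 percentage points lower from compound 1 to compound 2 (beyond the scatter). Compound 3 differs from compound 1 in the core, where (1H-1,2,4-triazol-1-yl in place of 4-methylpiperazin-1-yl on an aromatic carbon); that step was a number 27.4 percentage points lower from compound 1 to compound 3 (beyond the scatter). The values of compound 2 and compound 3 lie within the scatter of each other.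

Compound 4 `CN(C)c1ccc(C2CC(c3ccc(-n4cncn4)cc3)=NN2S(C)(=O)=O)cc1` has not yet been measured. It differs from compound 3 as methylsulfonyl in place of (2-phenylethenyl)carbonyl on an amine nitrogen in a ring This is the same kind of change as that from compound 1 to compound 2, though the surroundings differ: the ring atom two ring bonds away bears a 4-(1H-1,2,4-triazol-1-yl)phenyl group in compound 3, and a large group in compound 1.

From compound 3 to compound 4 a step of a number 6.5 percentage points lower from compound 3 to compound 4 (within the scatter) is expected in this assay, smaller than the earlier one because compound 3 already stands at 8.5% and inhibition cannot fall far below nothing. Compound 4 is thus estimated at 2%, between -6% and 11%.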

Compound 4, a percentage reported as inhibition, at one concentration (the size of the read-out at that concentration, not a potency): 7.8%
Beside the measured number, compound 4's estimate is 5.8 percentage points below it; the measured number falls inside the stated range.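

In this assay, putting methylsulfonyl in place of (2-phenylethenyl)carbonyl on the ring nitrogen did not carry over from one core to the other with the same size: the same change on two cores in this assay, a number 35.3 percentage points lower (beyond the scatter) from compound 1 to compound 2 and a number 0.7 percentage points lower (within the scatter) from compound 3 to compound 4, 34.6 percentage points apart, beyond the scatter of two such steps On the core of compound 3 this change gave a number 0.7 percentage points lower from compound 3 to compound 4 (within the scatter), and the exchange of 4-methylpiperazin-1-yl for 1H-1,2,4-triazol-1-yl, read on the methylsulfonyl compounds, gave a number 7.2 percentage points higher from compound 2 to compound 4 (within the scatter), so that the two changes do not add up: the same change on two cores in this assay, a number 27.4 percentage points lower (beyond the scatter) from compound 1 to compound 3 and a number 7.2 percentage points higher (within the scatter) from compound 2 to compound 4, 34.6 percentage points apart, beyond the scatter of two such steps This shows that the high value of compound 1 needs both of its groups together among these four compounds, but it rests on one set of pairs, and with compound 2, compound 3 and compound 4 all near the bottom of the scale it does not show why, nor how the change would behave on a core with more inhibition to lose.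

From the compounds shown here alone, it remains open whether a smaller acyl group such as acetyl on the ring nitrogen would keep the inhibition seen with compound 1. Going by these compounds, it is equally open whether another amine on the aromatic carbon, such as morpholin-4-yl, could stand in for the 4-methylpiperazin-1-yl group.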